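Swapping 1,1-difluoroethyl for ethoxy on a shared core

The compounds below may be only part of what the source reports. "The series", "measured", "known", "first", "only" and "open" are said of these compounds alone.

In an ADME assay on a cell-free system (plasma, Homo sapiens) for protein binding, three compounds built on one shared core have been measured. Compound 1 (`COCCc1nc2nc(C)cc(Nc3ccc(S(F)(F)(F)(F)F)cc3)n2n1`) gives 87.7% and compound 2 (`COCc1nc2nc(C)cc(Nc3ccc(S(F)(F)(F)(F)F)cc3)n2n1`) gives 91.7%. These two sit close together, with a 1.5-fold lower unbound fraction from compound 1 to compound 2 (0.17 log units; within the scatter) as the only difference. Compound 3 (`Cc1cc(Nc2ccc(S(F)(F)(F)(F)F)cc2)n2nc(C(C)(F)F)nc2n1`) stands at 97.4% and has the lowest unbound fraction of the three, apart from both others by more than the scatter.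

Compound 4 (`CCOc1nc2nc(C)cc(Nc3ccc(S(F)(F)(F)(F)F)cc3)n2n1`) has not yet been measured. It differs from compound 3 as follows (ethoxy in place of 1,1-difluoroethyl on an aromatic carbon): ethoxy in place of 1,1-difluoroethyl on an aromatic carbon.

Going by the values given here, two measured steps bear on this change. Both a 3.2-fold lower unbound fraction from compound 2 to compound 3 (0.50 log units; beyond the scatter) and a 4.7-fold lower unbound fraction from compound 1 to compound 3 (0.67 log units; beyond the scatter) are modest, and each puts 1,1-difluoroethyl in place of a chain that holds an oxygen. Ethoxy also holds an oxygen, so the change to compound 4 resembles these two steps run in reverse. Among the compounds with values here, no measured compound carries ethoxy itself, which keeps the range wide. In this assay a modest move toward more free compound is therefore expected (a 2.7-fold higher unbound fraction from compound 3 to compound 4 (0.43 log units; beyond the scatter)), about as large as the smaller of the two steps. Compound 4 is estimated at 93% (expected range from 88% to 96.5%).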

Compound 4, plasma protein binding in the plasma assay: 97.7%
Estimate against measurement, compound 4: 3.0-fold (0.48 log units) (unbound fraction) above, and the stated range ends below it.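

In the plasma assay, ethoxy in place of 1,1-difluoroethyl on this aromatic carbon gives a 1.1-fold lower unbound fraction from compound 3 to compound 4 (0.05 log units; within the scatter), so among these compounds an oxygen in the group does not by itself go with more free compound. Ethoxy instead parts from the two other oxygen-bearing chains, with a 3.6-fold lower unbound fraction from compound 2 to compound 4 (0.56 log units; beyond the scatter) and a 5.3-fold lower unbound fraction from compound 1 to compound 4 (0.73 log units; beyond the scatter), although it is attached to the aromatic carbon through its oxygen while methoxymethyl and 2-methoxyethyl are attached through carbon. The change is not silent everywhere, for the two compounds that the plasma assay does not separate stand apart in a physicochemical assay for solubility, at pH 6.5 (a higher number here means a more soluble compound, a lower number a less soluble compound), where compound 3 gives 30000 nM and compound 4 gives 4000 nM: the measured solubility of compound 3, 30000 nM, and of compound 4, 4000 nM, a 7.5-fold lower number (0.88 log units; beyond the scatter).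

The compounds shown cannot separate the way ethoxy is attached from its chain length and shape, since these differ together across the three oxygen-bearing groups. Going by these compounds, whether methoxy, propoxy or an amine at this place would stay with compound 3 and compound 4 in the plasma assay, or move toward compound 1 and compound 2, remains open, as does the way each would change the reading in the physicochemical assay.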